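Swapping a cyclic amine for a cyclohexylamino group

The compounds below may be only part of what the source reports. "The series", "measured", "known", "first", "only" and "open" are said of these compounds alone.

Compound 1 `O=C1C(N2CCCC2)=CC(=O)c2c1nc1n2[C@H]2OC[C@@H](O)[C@H]2OC1` carries a pyrrolidin-1-yl group on the shared core. In a functional assay on ECa-109 cells for inhibition, with ECa-109 cell line (Homo sapiens) as the target, read by sulforhodamine B assay (on this read-out higher numbers stand for weaker inhibition and lower numbers for stronger inhibition), compound 1 gives > 16000 nM, which is a limit of the assay and not a number. Compound 2 `O=C1C=C(Nc2ccc(Br)cc2)C(=O)c2c1nc1n2[C@H]2OC[C@@H](O)[C@H]2OC1` gives 2850 nM in this assay. Compound 3 `COc1ccc(NC2=CC(=O)c3nc4n(c3C2=O)[C@H]2OC[C@@H](O)[C@H]2OC4)cc1` gives > 4000 nM in this assay, a limit and not a number. Within the data shown here, the one measured step, an at least 1.4-fold higher number from compound 2 to compound 3 (0.14 log units; that floor lies within the scatter), concerns a change on an aromatic ring and does not touch the amine itself, so it bears only loosely on the present change. Compound 4 `O=C1C(NC2CCCCC2)=CC(=O)c2c1nc1n2[C@H]2OC[C@@H](O)[C@H]2OC1` differs from compound 1 as follows: cyclohexylamino in place of pyrrolidin-1-yl on a double-bonded ring carbon. Compounds 2 and 3 both carry an amine hydrogen at this position, and compound 2 reaches a measurable value, so some gain in this assay is expected for compound 4, though from a limit the size is uncertain. The expected step is an at least 2.0-fold lower number from compound 1 to compound 4 (0.30 log units; that floor lies within the scatter). Compound 4 is estimated at 8000 nM, within 3000 nM to 25000 nM.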

Compound 4, half-maximal inhibitory concentration: > 16000 nM
Compound 4: a limit, no number; the forecaster's own chance of this, stated with the estimate: 40%; middle value at least 2.0-fold (0.30 log units) away from the limit.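

Compound 1 and compound 4 each give only a limit in this assay, so no step between them can be read: the limit of > 16000 nM in this assay, at which 2 of the 4 values shown sit.

The compounds shown leave open whether cyclohexylamino in place of pyrrolidin-1-yl on the shared core changes inhibition at all.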